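Quaternary charged chain end on the lysine-type amide, compound 4

The compounds below may be only part of what the source reports. "The series", "measured", "known", "first", "only" and "open" are said of these compounds alone.

Compound 1 `Cc1cc(C)c2cccc(OCc3c(Cl)ccc(S(=O)(=O)NC4(C(=O)N5CCN(C(=O)[C@@H](N)CCCCN)CC5)CCCC4)c3Cl)c2n1` carries a 1,5-diaminopentyl on the carbonyl carbon of the amide that caps the shared core. In an assay on isolated protein for binding affinity to B1 bradykinin receptor (Homo sapiens) (on this read-out higher numbers stand for weaker inhibition and lower numbers for stronger inhibition), compound 1 gives < 10000 nM, which is a limit of the assay and not a number. Compound 2 `Cc1cc(C)c2cccc(OCc3c(Cl)ccc(S(=O)(=O)NC4(C(=O)N5CCN(C(=O)[C@H](CCCCN(C)C)N(C)C)CC5)CCCC4)c3Cl)c2n1` likewise returns only a limit, < 10000 nM. Compound 3 `Cc1cc(C)c2cccc(OCc3c(Cl)ccc(S(=O)(=O)NC4(C(=O)N5CCN(C(=O)C[C@@H](N)CCC[N+](C)(C)C)CC5)CCCC4)c3Cl)c2n1` also returns only a limit, < 10000 nM. Among the compounds with values here, every value so far sits at the limit of < 10000 nM in this assay, at which 3 of the 3 values shown sit, so the changes between these three compounds read as a step that the two limits leave unreadable from compound 1 to compound 2, a step that the two limits leave unreadable from compound 1 to compound 3 and a step that the two limits leave unreadable from compound 2 to compound 3: none of them can be sized, and none gives a direction.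

Compound 4 `Cc1cc(C)c2cccc(OCc3c(Cl)ccc(S(=O)(=O)NC4(C(=O)N5CCN(C(=O)[C@@H](N)CCC[N+](C)(C)C)CC5)CCCC4)c3Cl)c2n1` differs from compound 1 by a group of 4 heavy atoms (3 carbon, 1 nitrogen; no ring) in place of a group of 2 heavy atoms (1 carbon, 1 nitrogen; no ring), on a saturated chain carbon, four bonds along the chain from an amine nitrogen and a carbonyl carbon. The closest measured neighbour is compound 3, whose chain likewise carries a net positive charge and which also stopped at the limit. With nothing readable in any measured step, no step beyond the scatter is expected for a step that the limit leaves unreadable from compound 1 to compound 4. Compound 4 is therefore expected to give 3000 nM in this assay, most likely reported again as a limit. The expected range for compound 4 runs from 300 nM to 10000 nM.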

Compound 4, inhibition constant: < 10000 nM
Compound 4 ended at the assay's limit (the forecaster's own chance of this, stated with the estimate: 80%); the middle value does not contradict the limit.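

In this assay compound 4 gives < 10000 nM, a limit of the assay and not a number. Its steps from compound 1, compound 2 and compound 3 cannot be read: the limit of < 10000 nM in this assay, at which 4 of the 4 values shown sit.

The compounds shown leave open how far any of these changes on the amide cap moves the value in this assay, and in which direction.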